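Swapping a Halogen on the Sulfonyl Ring

The source may report more compounds than this note shows. Statements on the series, on what has been measured and on what is new or still open speak of the compounds shown alone.

Compound 1, `O=C1/C(=C/c2cccnc2)CN(S(=O)(=O)c2ccc(F)cc2)C/C1=C\c1ccccc1C(F)(F)F`, gives 6390 nM in a functional assay on SMMC-7721 cells (Homo sapiens) for cytotoxicity, read by MTT assay, with a stated time of 24 h; on this read-out higher numbers stand for weaker inhibition and lower numbers for stronger inhibition.
Compound 2, `O=C1/C(=C/c2cccnc2)CN(S(=O)(=O)c2ccc(Cl)cc2)C/C1=C\c1ccccc1C(F)(F)F`, gives 4880 nM in this assay.
Compound 3, `O=C1/C(=C/c2ccncc2)CN(S(=O)(=O)c2ccc(F)cc2)C/C1=C\c1ccccc1C(F)(F)F`, gives 9270 nM in this assay.

The three measured compounds share one core and differ at only two places. Compound 1 and compound 2 are told apart by chloro in place of fluoro on an aromatic carbon, and this change made a 1.3-fold lower number from compound 1 to compound 2 (0.12 log units; within the scatter). Compound 1 and compound 3 have the same atoms joined differently: pyridin-4-yl in place of pyridin-3-yl on a double-bonded chain carbon bound to a double-bonded ring carbon, and this made a 1.5-fold higher number from compound 1 to compound 3 (0.16 log units; within the scatter). The values of compound 2 and compound 3 also lie within the usual scatter of each other, so none of the three can be singled out as stronger or weaker on this evidence.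

Compound 4, `O=C1/C(=C/c2ccncc2)CN(S(=O)(=O)c2ccc(Cl)cc2)C/C1=C\c1ccccc1C(F)(F)F`, has not yet been measured. It differs from compound 3 by chloro in place of fluoro on an aromatic carbon. The place of this change reads the same, word for word, as the change from compound 1 to compound 2, so it is the same change, made once more on a core that carries pyridin-4-yl instead of pyridin-3-yl.

Within the data shown here, the expected step from compound 3 to compound 4 is therefore a 1.3-fold lower number from compound 3 to compound 4 (0.12 log units; within the scatter), because a 1.3-fold lower number from compound 1 to compound 2 (0.12 log units; within the scatter) is the only measured instance of this change. Compound 4 is estimated at 7100 nM, with a plausible range from 3500 nM to 14000 nM.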

Compound 4, half-maximal inhibitory concentration: 5510 nM
For compound 4 the middle estimate is 1.3-fold (0.11 log units) above the measured one; the measured number falls inside the stated range.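

Chloro in place of fluoro gives a 1.7-fold lower number from compound 3 to compound 4 (0.23 log units; within the scatter) in this assay, and this step agrees with the earlier one: the same change on two cores in this assay, a 1.3-fold lower number (0.12 log units; within the scatter) from compound 1 to compound 2 and a 1.7-fold lower number (0.23 log units; within the scatter) from compound 3 to compound 4, 1.3-fold (0.11 log units) apart, within the scatter of two such steps

Pyridin-4-yl in place of pyridin-3-yl gives a 1.1-fold higher number from compound 2 to compound 4 (0.05 log units; within the scatter), and this step also agrees with its earlier counterpart: the same change on two cores in this assay, a 1.5-fold higher number (0.16 log units; within the scatter) from compound 1 to compound 3 and a 1.1-fold higher number (0.05 log units; within the scatter) from compound 2 to compound 4, 1.3-fold (0.11 log units) apart, within the scatter of two such steps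

Each change therefore looks alike on the two cores, but every step here lies within the scatter, so the series shows no clear effect of either change, and this agreement cannot establish that a real effect carries from one core to another.

The compounds shown leave open whether a different group in place of the halogen on the sulfonyl ring, such as a methoxy group, an amine or a carboxylic acid, would move the number beyond the scatter. From the compounds shown here alone, it also remains open whether replacing the trifluoromethyl group with a nitrile, or the pyridine ring with a plain phenyl ring, would separate any compounds in this assay.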